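The compounds below may be only part of what the source reports. "The series", "measured", "known", "first", "only" and "open" are said of these compounds alone.

Going by the values given here, in a functional assay on BXPC-3 cells (Homo sapiens) for cytotoxicity, read by MTT assay (on this read-out lower numbers stand for stronger inhibition and higher numbers for weaker inhibition), compound 1 `Oc1ccc(CN(Cc2ccccc2C(F)(F)F)Cc2ccc(O)c3ncccc23)c2cccnc12` gives 274 nM and compound 2 `Oc1ccc(CN(Cc2cccc(I)c2)Cc2ccc(O)c3ncccc23)c2cccnc12` gives 2590 nM, the higher of the two numbers so far. Compound 3 `Oc1ccc(CN(Cc2cccs2)Cc2ccc(O)c3ncccc23)c2cccnc12` carries thiophen-2-yl in place of 3-iodophenyl on a saturated chain carbon bound to an amine nitrogen. Among the compounds with values here, the only measured step at this place is a 9.5-fold higher number from compound 1 to compound 2 (0.98 log units; beyond the scatter), which is modest but beyond the scatter. No five-membered aromatic ring has been measured here, so the direction is uncertain. A modest step to a lower number is expected, a 2.2-fold lower number from compound 2 to compound 3 (0.33 log units; beyond the scatter). The estimate for compound 3 is 1200 nM, with an expected range of 350 nM to 3800 nM.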

Compound 3, half-maximal inhibitory concentration: 89 nM
Compound 3: middle estimate off by 13-fold (1.13 log units), on the high side, outside the stated range (below it).
By their numbers in this assay, from the lowest: compound 3; then compound 1; then compound 2.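

In this assay, the place on a saturated chain carbon bound to an amine nitrogen also accepts a five-membered aromatic ring with 1 hetero atom: thiophen-2-yl brings a 29-fold lower number from compound 2 to compound 3 (1.46 log units; beyond the scatter) and a 3.1-fold lower number from compound 1 to compound 3 (0.49 log units; beyond the scatter). A six-membered aromatic ring of carbon only is therefore not required here, and compound 3 has the lowest number of the three, with both steps beyond the scatter. Nothing available explains these steps.

Still open, as far as these compounds go, is whether the sulfur or the smaller ring accounts for them. A furan-2-yl or an unsubstituted phenyl at the same place would separate the two.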